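Compound 1 to compound 4: one group exchanged on the chain

A few compounds are considered here, and "the series" means these few. Any claim that something is new, unique, unknown or untested is made for them only; others in the source may bear on it.

Measured so far:
compound 1, `CCC/N=C(/NC#N)NCCCn1nc(-c2ccccc2)ccc1=O`, this read-out 100 mg/kg
compound 2, `O=c1ccc(-c2ccccc2)nn1CCCCNC(=S)Nc1cccc2ccccc12`, > 100 mg/kg, a limit of the assay
compound 3, `CC/N=C(/NC#N)NCCCn1nc(C)ccc1=O`, > 100 mg/kg, a limit of the assay

The read-out is a functional assay on the whole organism (stomach) with Rattus norvegicus as the target; on this read-out higher numbers stand for an effect only at larger amounts of compound and lower numbers for an effect already at smaller amounts. Among the compounds with values here, compound 1 gives 100 mg/kg in this assay, and that is the only number among the three results. For compound 2 the result is > 100 mg/kg, which is a limit of the assay and not a number. For compound 3 the result is likewise > 100 mg/kg, again a limit and not a number. What the set shows is therefore (the limit of > 100 mg/kg in this assay, at which 2 of the 3 values shown sit), with compound 1 as the one that gives a dose.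

Compound 4, `CC/N=C(\S)NCCCn1nc(-c2ccccc2)ccc1=O`, has not yet been measured. It differs from compound 1 in one place: a group of 5 heavy atoms (3 carbon, 1 nitrogen, 1 sulfur; no ring) in place of a group of 8 heavy atoms (5 carbon, 3 nitrogen; no ring), on an amine nitrogen. Within the data shown here, no pair of measured compounds that differ in a single place is available, so the size of such a step is not known from these data. With compound 1 as the only anchor, the step of no change at the digits printed from compound 1 to compound 4 (within the scatter) is expected to be small, no further than the usual scatter in either direction. For compound 4 in this assay the estimated value is 100 mg/kg, within a range from 30 mg/kg to 300 mg/kg.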

Compound 4, dose for half-maximal effect: > 100 mg/kg
Compound 4 ended at the assay's limit; the forecaster's own chance of this, stated with the estimate: 45%; the middle value lies on the limit itself.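

On the amine nitrogen whose other neighbour is a saturated chain carbon, putting a group of 5 heavy atoms (3 carbon, 1 nitrogen, 1 sulfur; no ring) in place of a group of 8 heavy atoms (5 carbon, 3 nitrogen; no ring) gives, in this assay, this step: a number no lower from compound 1 to compound 4 (the limit leaves the size open). This is the first pair shown that differs in one place, and it says only that this exchange on the chain gives no lower number than compound 1; the size of the step cannot be read. Compound 1 remains the only compound with a number, and the results now gather at one end of the scale: the limit of > 100 mg/kg in this assay, at which 3 of the 4 values shown sit.

The exchange also changes several things at once, as the entering group brings in sulfur and lacks the triple bond of the leaving group, so the pair leaves open which of these differences counts and how far compound 4 lies from compound 1. Also open, on these data alone, is what a urea with a carbonyl in place of the sulfur, or a carboxylic acid on this amine nitrogen, would give.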